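Acetylpiperazine replacing dimethylamino on the pyrimidine-type core

This account rests on a few compounds, and the source may have more. Where it says the series, first, only, none or still open, it means among the compounds named here.

Measured compounds:
- compound 1 `CC(=O)N1CCN(c2nc3c(c(-c4ccccc4C)n2)C(=O)N(Cc2cc(C(F)(F)F)cc(C(F)(F)F)c2)C[C@@H](C)CO3)CC1`: 0.345 nM
- compound 2 `Cc1ccccc1-c1ncnc2c1C(=O)N(Cc1cc(C(F)(F)F)cc(C(F)(F)F)c1)C[C@H](C)CO2`: 12.6 nM
- compound 3 `Cc1ccccc1-c1nc(N(C)C)nc2c1C(=O)N(Cc1cc(C(F)(F)F)cc(C(F)(F)F)c1)C[C@H](C)CO2`: 0.427 nM

In a functional assay on ileum for antagonist activity at Substance-P receptor (Cavia porcellus) (on this read-out lower numbers stand for stronger inhibition and higher numbers for weaker inhibition), compound 3 gives 0.427 nM and stands second highest of the three numbers; its nearest neighbour is compound 1, within the scatter of it, and its furthest is compound 2, with a far higher number. Among the compounds with values here, the one step measured in this assay, a 30-fold lower number from compound 2 to compound 3 (1.47 log units; beyond the scatter), shows that occupying this position with a nitrogen-linked group carries a large gain.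

Compound 4 `CC(=O)N1CCN(c2nc3c(c(-c4ccccc4C)n2)C(=O)N(Cc2cc(C(F)(F)F)cc(C(F)(F)F)c2)C[C@H](C)CO3)CC1` is not yet measured. It differs from compound 3 in that (4-acetylpiperazin-1-yl in place of dimethylamino on an aromatic carbon). Within the data shown here, no measured step bears directly on this exchange; what can be said is that compound 1, which carries the same entering group, gives 0.345 nM in this assay, within the scatter of compound 3. The step of a 1.1-fold lower number from compound 3 to compound 4 (0.03 log units; within the scatter) is therefore expected to stay within the scatter. Compound 4 is estimated at 0.4 nM in this assay, with a range from 0.15 nM to 1.2 nM.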

Compound 4, antagonist equilibrium constant: 0.139 nM
The estimate for compound 4 lay 2.9-fold (0.46 log units) above the measured number, outside the stated range (below it).
By their numbers in this assay, from the lowest: compound 4; then compounds 1 and 3 (each within the scatter of the next); then compound 2.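

In this assay, 4-acetylpiperazin-1-yl and dimethylamino are not interchangeable on this aromatic carbon: a 3.1-fold lower number from compound 3 to compound 4 (0.49 log units; beyond the scatter) is a modest step, but it lies beyond the scatter. Measured against hydrogen at the same place, the 4-acetylpiperazin-1-yl group gives a 91-fold lower number from compound 2 to compound 4 (1.96 log units; beyond the scatter), so the large gain seen with dimethylamino extends further with this group. Configuration also counts in this series, and the step of a 2.5-fold lower number from compound 1 to compound 4 (0.39 log units; beyond the scatter) can be assigned to the stereocentre at a saturated ring carbon, drawn S in compound 4, because of the following: the fact that compounds 1 and 4 differ only in the configuration as drawn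

Going by these compounds, whether the extra gain depends on the acetyl group or on the piperazine ring alone remains open, as does the outcome with a free piperazine or a morpholine on this carbon. Also open, on these data alone, is whether the same configuration preference holds with dimethylamino or hydrogen at this place.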